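Pyridin-4-yl in Place of Phenyl in Compound 4

The source may report more compounds than this note shows. Statements on the series, on what has been measured and on what is new or still open speak of the compounds shown alone.

Compound 1 `CC(C)(C)n1cc2c(n1)C(=O)CC1(CCN(C(=O)c3cc(-c4ccccc4)nc4ccccc34)CC1)O2` was tested in a functional assay on MDA-MB-231 cells (Homo sapiens) for inhibition, read by MTT assay, with a stated time of 72 h; a higher number here means a weaker inhibitor, a lower number a stronger inhibitor. In this assay compound 1 gives only a limit, > 10000 nM. Compound 2 `COc1ccc(-c2cc(C(=O)N3CCC4(CC3)CC(=O)c3nn(C(C)(C)C)cc3O4)c3ccccc3n2)cc1` likewise gives only a limit in this assay, > 10000 nM. Compound 3 `CC(C)(C)n1cc2c(n1)C(=O)CC1(CCN(C(=O)c3cc(-c4ccccn4)nc4ccccc34)CC1)O2` gives 8100 nM in this assay. Two of the three values shown thus sit at the limit of > 10000 nM in this assay, at which 2 of the 3 values shown sit, so compound 1 stands at that limit with no number of its own. The step that the two limits leave unreadable from compound 1 to compound 2. The step of an at least 1.2-fold lower number from compound 1 to compound 3 (0.09 log units; that floor lies within the scatter), and the step of an at least 1.2-fold lower number from compound 2 to compound 3 (0.09 log units; that floor lies within the scatter).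

Compound 4 `CC(C)(C)n1cc2c(n1)C(=O)CC1(CCN(C(=O)c3cc(-c4ccncc4)nc4ccccc34)CC1)O2` differs from compound 1 by pyridin-4-yl in place of phenyl on an aromatic carbon. The step from compound 1 to compound 3, pyridin-2-yl in place of phenyl, is the nearest guide, and its floor lies within the scatter. A pyridin-4-yl in place of phenyl is expected to behave much the same, so the expected step of a number no higher from compound 1 to compound 4 (the limit leaves the size open) is none beyond the scatter. Compound 4 is therefore expected to give about 10000 nM in this assay, within 5000 nM to 25000 nM, and may well be reported only as a limit.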

Compound 4, half-maximal inhibitory concentration: 1650 nM
Beside the measured number, compound 4's estimate is 6.1-fold (0.78 log units) above it; measured number below the stated range.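

Phenyl on this aromatic carbon, next to the ring nitrogen, had shown no step beyond the scatter with pyridin-2-yl, but pyridin-4-yl in its place gives an at least 6.0-fold lower number from compound 1 to compound 4 (0.78 log units; beyond the scatter). Where the nitrogen stands in the entering ring therefore matters in this assay, as pyridin-4-yl in place of pyridin-2-yl gives a 4.9-fold lower number from compound 3 to compound 4 (0.69 log units; beyond the scatter). Pyridin-4-yl in place of 4-methoxyphenyl gives an at least 6.0-fold lower number from compound 2 to compound 4 (0.78 log units; beyond the scatter), and this size and that of the step from phenyl are only floors because compounds 1 and 2 each stand at a limit: the limit of > 10000 nM in this assay, at which 2 of the 4 values shown sit.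

The compounds shown leave open whether pyridin-3-yl would fall with compound 3 or with compound 4. They also leave open whether a 4-aminophenyl group or a pyrimidin-4-yl ring at this place would match compound 4.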